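Swapping 2-carboxyethyl for 2-carboxycyclopropyl in compound 1

A few compounds are considered here, and "the series" means these few. Any claim that something is new, unique, unknown or untested is made for them only; others in the source may bear on it.

Measured so far:
- compound 1 `Cc1cc(CCC(=O)O)ccc1-c1noc(-c2ccc(OC(C)C)c(C#N)c2)n1` (2.3 mL/min/kg)
- compound 2 `Cc1cc([C@@H]2C[C@H]2C(=O)O)ccc1-c1noc(-c2ccc(OC(C)C)c(C(F)(F)F)c2)n1` (2.4 mL/min/kg)
- compound 3 `Cc1cc(C(C)CC(=O)O)ccc1-c1noc(-c2ccc(OC(C)C)c(C(F)(F)F)c2)n1` (2.9 mL/min/kg)

In an in vivo ADME assay on the whole organism (plasma, strain Sprague-Dawley) for pharmacokinetics, with Rattus norvegicus as the target (a higher number here means faster removal of the compound, a lower number slower removal), compound 1 gives 2.3 mL/min/kg and stands within the scatter of both compound 2 and compound 3. Compound 4 `Cc1cc([C@H]2C[C@H]2C(=O)O)ccc1-c1noc(-c2ccc(OC(C)C)c(C#N)c2)n1` differs from compound 1 by one change 2-carboxycyclopropyl in place of 2-carboxyethyl on an aromatic carbon and carries 2-carboxycyclopropyl in place of 2-carboxyethyl on an aromatic carbon. Among the compounds with values here, one measured step bears on this side chain. The step of a 1.2-fold higher number from compound 2 to compound 3 (0.08 log units; within the scatter) puts 1-(carboxymethyl)ethyl in place of 2-carboxycyclopropyl on an aromatic carbon and stays within the scatter. Compound 2 has trifluoromethyl where compound 1 has nitrile, and it differs from compound 4 in the arrangement at a defined stereocentre. Even so, compound 2 already carries 2-carboxycyclopropyl and gives 2.4 mL/min/kg in this assay without leaving the scatter of compound 1. No step beyond the scatter is therefore expected, and the data favour no direction. The estimated step is a 1.1-fold higher number from compound 1 to compound 4 (0.04 log units; within the scatter) and should stay within the scatter. For compound 4 the expected clearance is 2.5 mL/min/kg with an estimated range from 1.3 mL/min/kg to 4.8 mL/min/kg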

Compound 4, clearance: 1.2 mL/min/kg
Compound 4: the middle estimate sits 2.1-fold (0.32 log units) above what was measured; measured number below the stated range.
By their numbers in this assay, from the lowest: compounds 4, 1, 2 and 3 (each within the scatter of the next, the first and the last beyond it).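

Within the data shown here, the pair of compound 1 and compound 4 isolates the change at this position, on an aromatic carbon para to a large group, whereas the earlier compounds spoke to it only through compound 2, which carries trifluoromethyl in place of nitrile and a different stereocentre arrangement. In this assay, replacing 2-carboxyethyl with 2-carboxycyclopropyl, with its three-membered ring and two defined stereocentres, stays within the scatter (a 1.9-fold lower number from compound 1 to compound 4 (0.28 log units; within the scatter)), so on this core the ring is tolerated without a step that can be told from noise. Nothing measured here offers an explanation for this result.

As far as these compounds go, whether the arrangement at the stereocentres matters on the nitrile core remains open. So does whether a longer chain ending in a carboxylic acid, or an amine in place of the carboxylic acid, would stay within the scatter at this position.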